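The source may report more compounds than this note shows. Statements on the series, on what has been measured and on what is new or still open speak of the compounds shown alone.

Working notes on the series. Three compounds carry numbers in a functional assay on HEp-2 cells (Homo sapiens) for cytotoxicity, read by sulforhodamine B assay, with a stated time of 48 h; on this read-out lower numbers stand for stronger inhibition and higher numbers for weaker inhibition. Compound 1 `COc1cc(C2CC(c3cccc4ccccc34)=NN2C(C)=O)cc(OC)c1OC` gives 1010 nM in this assay, compound 3 `COc1ccc(C2CC(c3ccc4ccccc4c3)=NN2CC=O)c(OC)c1OC` gives 590 nM, and compound 2 `O=CCN1N=C(c2ccc3ccccc3c2)CC1c1cccc([N+](=O)[O-])c1` gives 3870 nM, the highest of the three numbers; its gap to compound 1 and to compound 3 lies beyond the scatter in each case. Going by the values given here, no pair of measured compounds differs in a single place, so no measured step is available. Compound 4 `O=CCN1N=C(c2ccc3ccccc3c2)CC1c1cccc(Br)c1` differs from compound 2 by bromo in place of nitro on an aromatic carbon. Among the compounds with values here, with no measured step of this kind, the expectation is a small change from compound 2 to compound 4, estimated as a 1.3-fold lower number from compound 2 to compound 4 (0.11 log units; within the scatter), not clearly beyond the scatter. Compound 4 is expected to give about 3000 nM in this assay, with a range from 1200 nM to 7500 nM.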

Compound 4, half-maximal inhibitory concentration: 8780 nM
Compound 4: middle estimate off by 2.9-fold (0.47 log units), on the low side; the whole stated range lies below it.
By their numbers in this assay, from the lowest: compounds 3 and 1 (each within the scatter of the next); then compound 2; then compound 4.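

In this assay, bromo in place of nitro on this aromatic carbon gives a 2.3-fold higher number from compound 2 to compound 4 (0.36 log units; beyond the scatter) and so shows that the number responds to the group at this position, meta to a large group. Of this pair, the 3-nitrophenyl compound holds the lower number. No evidence on the two groups accounts for the step. Open, going by these compounds, is how an amine or a carboxylic acid on the same aromatic carbon would read, and whether the same exchange gives a similar step on the cores of compound 1 and compound 3.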